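A few compounds are considered here, and "the series" means these few. Any claim that something is new, unique, unknown or untested is made for them only; others in the source may bear on it.

Compound 3 `Fc1ccc(Nc2ccnc(NCCCNc3ccnc4cc(Cl)ccc34)n2)cc1` gives 13700 nM in an ADME assay on Vero cells (Chlorocebus sabaeus) for cytotoxicity, read by neutral red uptake, with a stated time of 72 h (a lower number here means a stronger inhibitor, a higher number a weaker inhibitor), and thus holds the highest of the two numbers reported there, though compound 1 `Cc1ccc(Nc2ccnc(NCCNc3ccnc4cc(Cl)ccc34)n2)cc1` with 13600 nM lies within the scatter of it. Compound 2 `COc1cc(Nc2ccnc(NCCNc3ccnc4cc(Cl)ccc34)n2)cc(OC)c1` is recorded in this assay as "not active" (no number reported) without a number. Compound 4 `COc1ccc(Nc2ccnc(NCCCNc3ccnc4cc(Cl)ccc34)n2)cc1` differs from compound 3 in one place: methoxy in place of fluoro on an aromatic carbon. Going by the values given here, no pair of measured compounds separated by a single change is available, so the size of this step can only be judged from the spread of the numbers as they stand. Compound 4 is expected to sit close to compound 3, with a step of a 1.2-fold higher number from compound 3 to compound 4 (0.07 log units; within the scatter) that stays within the scatter, and its estimated value in this assay is 16000 nM, between 7000 nM and 40000 nM.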

Compound 4, half-maximal inhibitory concentration: 13300 nM
Estimate against measurement, compound 4: 1.2-fold (0.08 log units) above; the measured number falls inside the stated range.
By their numbers in this assay, from the lowest: compounds 4, 1 and 3 (each within the scatter of the next).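

Going by these compounds alone, the first single-change step in this assay shows that methoxy in place of fluoro on this aromatic carbon, para to a large group, gives a 1.0-fold lower number from compound 3 to compound 4 (0.01 log units; within the scatter). At this position, then, going from 4-fluorophenyl to 4-methoxyphenyl does not separate the two compounds in this read-out. No measured evidence bears on this result. From the compounds shown here alone, whether an amine or a carboxylic acid at the same position would give a step beyond the scatter remains open. So does whether a longer chain would leave this exchange equally silent.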